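The source may hold more compounds than are shown below. What is called first, only, known or untested is meant among the compounds shown, and "the series" means these compounds.

Working notes on the series. Among the measured compounds shown here, compound 1 `Cc1nc2cc(NC(=O)N3CCN(Cc4cccc(Oc5ccc(Cl)cc5)c4)CC3)ccc2o1` gives 7.7 nM in an assay on isolated protein for inhibition of Fatty-acid amide hydrolase 1 (Homo sapiens), with a stated time of 60 min (a higher number here means a weaker inhibitor, a lower number a stronger inhibitor), the lowest of the three numbers measured so far. Compound 2 `O=C(Nc1noc2cccnc12)N1CCN(Cc2cccc(Oc3ccc(Cl)cc3)c2)CC1` gives 13 nM, a step of a 1.7-fold higher number from compound 1 to compound 2 (0.23 log units; within the scatter), while compound 3 `O=C(Nc1ccc2nccn2c1)N1CCN(Cc2cccc(Oc3ccc(Cl)cc3)c2)CC1` gives 100 nM, a step of a 13-fold higher number from compound 1 to compound 3 (1.11 log units; beyond the scatter); between those two the step is a 7.7-fold higher number from compound 2 to compound 3 (0.89 log units; beyond the scatter).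

Compound 4 `O=C(Nc1cccc2nccn12)N1CCN(Cc2cccc(Oc3ccc(Cl)cc3)c2)CC1` is not yet measured. The change from compound 1 is a group of 9 heavy atoms (7 carbon, 2 nitrogen; one five-membered aromatic ring with 2 hetero atoms, one six-membered aromatic ring with 1 hetero atom) in place of a group of 10 heavy atoms (8 carbon, 1 nitrogen, 1 oxygen; one five-membered aromatic ring with 2 hetero atoms, one six-membered aromatic ring of carbon only), on an amide-type nitrogen. The entering group has the same atom count as the one that enters in the step from compound 1 to compound 3, attached at a different point of the same bicycle, so that step, a 13-fold higher number from compound 1 to compound 3 (1.11 log units; beyond the scatter), is the one that bears most directly on this case; the step of a 1.7-fold higher number from compound 1 to compound 2 (0.23 log units; within the scatter) shows that a bicycle carrying a ring nitrogen in its six-membered ring need not by itself cost potency. For the measured compounds named here, with only one comparable example, a weakening step is expected for compound 4 in this assay, of roughly a 10-fold higher number from compound 1 to compound 4 (1.02 log units; beyond the scatter), with the size uncertain. Compound 4 is therefore estimated at 80 nM, within a range of 30 nM to 250 nM.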

Compound 4, half-maximal inhibitory concentration: 2.7 nM
For compound 4 the middle estimate is 30-fold (1.47 log units) above the measured one, and the stated range ends above it.
By their numbers in this assay, from the lowest: compound 4; then compounds 1 and 2 (each within the scatter of the next); then compound 3.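

In this assay the point of attachment of the entering group decides the outcome: two groups with the same atom count, both on the amide-type nitrogen, differ by a 37-fold lower number from compound 3 to compound 4 (1.57 log units; beyond the scatter), so the weak number of compound 3 does not speak for the bicycle as a whole. With this attachment the group also improves on the 2-methyl-1,3-benzoxazol-5-yl group, with a 2.9-fold lower number from compound 1 to compound 4 (0.46 log units; beyond the scatter), and on the group of compound 2, with a 4.8-fold lower number from compound 2 to compound 4 (0.68 log units; beyond the scatter), making compound 4 the strongest inhibitor of the four. No data at hand explain these steps.

As far as these compounds go, whether the gain survives a methyl or a carboxylic acid on the entering group remains open. So does whether it holds when the chlorine of the shared core gives way to a trifluoromethyl.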